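Cyano for Fluoro: From Compound 3 to Compound 4

The source may report more compounds than this note shows. Statements on the series, on what has been measured and on what is new or still open speak of the compounds shown alone.

Measured compounds:
Compound 1 `Oc1ccccc1CNc1ccc(N2CCCCC2)cc1` — "not active" (no number reported)
Compound 2 `CN1CCN(c2ccc(NCc3ccccc3O)cc2)CC1` — "not active" (no number reported)
Compound 3 `Oc1ccccc1CNc1ccc(-c2ccc(F)cc2)cc1` — 3860 nM

For the measured compounds named here, in a functional assay on Jurkat cells (Homo sapiens) for activation, with a stated time of 24 h (on this read-out higher numbers stand for an effect only at larger amounts of compound and lower numbers for an effect already at smaller amounts), compound 3 is the only compound for which a number is reported; compound 1 and compound 2 are reported as not active in this assay, without a number. Compound 3 therefore stands alone as the single reference point. Compound 4 `N#Cc1ccc(-c2ccc(NCc3ccccc3O)cc2)cc1` differs from it by one change: cyano in place of fluoro on an aromatic carbon. Going by the values given here, no measured pair of compounds shows this change, so the size of its effect has no precedent here. The step expected from a 1.3-fold lower number from compound 3 to compound 4 (0.11 log units; within the scatter) is small, no larger than the usual scatter of this assay, in either direction. Compound 4 is expected to give about 3000 nM in this assay, within a range from 1000 nM to 9000 nM.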

Compound 4, half-maximal effective concentration: "not active" (no number reported)
Nothing numeric was reported for compound 4, so the estimate cannot be set against anything.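

For the compounds shown here, compound 4 carries no number, so no step from compound 3 can be read. On these data alone, what the change from fluoro to cyano does in this assay stays open for these compounds. No measured evidence bears on this result.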